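A Trifluoromethyl Added Twice, on Two Different Cores

The compounds below may be only part of what the source reports. "The series", "measured", "known", "first", "only" and "open" are said of these compounds alone.

Compound 1 `CC(O)(CSc1cccc(C(F)(F)F)c1)C(=O)Nc1ccc(S(F)(F)(F)(F)F)cc1` and compound 2 `CC(O)(CSc1cc(C(F)(F)F)cc(C(F)(F)F)c1)C(=O)Nc1ccc(S(F)(F)(F)(F)F)cc1` share one core, while compound 3 `CC(O)(COc1ccc(C#N)cc1)C(=O)Nc1ccc(S(F)(F)(F)(F)F)cc1` rests on another; the difference between the two cores is not broken down here. In a functional assay on DU-145 cells (Homo sapiens) for antiproliferative activity, read by propidium iodide staining, with a stated time of 96 h (on this read-out higher numbers stand for weaker inhibition and lower numbers for stronger inhibition), compound 1 gives 26200 nM, compound 2 gives 29700 nM, and compound 3 gives 32200 nM. The change from compound 1 to compound 2 is trifluoromethyl in place of hydrogen on an aromatic carbon, and it made a 1.1-fold higher number from compound 1 to compound 2 (0.05 log units; within the scatter). Compound 4 `CC(O)(COc1ccc(C#N)cc1C(F)(F)F)C(=O)Nc1ccc(S(F)(F)(F)(F)F)cc1` carries the same kind of change on the core of compound 3: trifluoromethyl in place of hydrogen on an aromatic carbon. The surroundings differ, though: in compound 2 the new group sits meta to a large group and meta to a trifluoromethyl group, whereas in compound 4 it sits ortho to a large group and meta to a cyano group. Because the earlier step of a 1.1-fold higher number from compound 1 to compound 2 (0.05 log units; within the scatter) stayed within the scatter, the expected step for compound 4 in this assay is small as well, a 1.1-fold higher number from compound 3 to compound 4 (0.02 log units; within the scatter). Compound 4 is thus estimated to give about 34000 nM in this assay, most likely between 20000 nM and 60000 nM.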

Compound 4, half-maximal inhibitory concentration: 21200 nM
The estimate for compound 4 lay 1.6-fold (0.21 log units) above the measured number, and the stated range covers the measured number.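

In this assay, placing trifluoromethyl on the second core gave a 1.5-fold lower number from compound 3 to compound 4 (0.18 log units; within the scatter). Set beside the same change on the first core, the two steps agree within the scatter of repeated measurements: the same change on two cores in this assay, a 1.1-fold higher number (0.05 log units; within the scatter) from compound 1 to compound 2 and a 1.5-fold lower number (0.18 log units; within the scatter) from compound 3 to compound 4, 1.7-fold (0.24 log units) apart, within the scatter of two such steps. On these two cores, then, the change gives a step within the scatter each time, but with a single pair per core this does not show that the cores respond alike, nor that the result would hold on a third core.

As far as these compounds go, it remains open whether an amine, a carboxylic acid or a chlorine atom in place of that hydrogen would give a step beyond the scatter. From the compounds shown here alone, no single change links the two cores here, so how they compare directly also stays open.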